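From ethyl to tert-butyl: compound 1 and compound 3

The compounds below may be only part of what the source reports. "The series", "measured", "known", "first", "only" and "open" are said of these compounds alone.

In a functional assay on A549 cells (Homo sapiens) for inhibition, read by CCK-8 assay, with a stated time of 72 h, tested at 2 uM (a lower number here means less inhibition of growth, a higher number more inhibition of growth at the concentration tested), compound 1 `CCc1ccc(SCc2ccc(C(=O)Nc3ccccc3N)cc2)cc1` gives 53.6% and compound 2 `Nc1ccccc1NC(=O)c1ccc(CSc2cccc(F)c2)cc1` gives 46.9%, so the two stand within the scatter of each other. Compound 3 `CC(C)(C)c1ccc(SCc2ccc(C(=O)Nc3ccccc3N)cc2)cc1` keeps the core of compound 1 with one change, tert-butyl in place of ethyl on an aromatic carbon. Going by the values given here, the only measured step, a number 6.7 percentage points lower from compound 1 to compound 2 (within the scatter), replaces the whole 4-ethylphenyl on the sulfur and stays small, so no step beyond the scatter is expected in this assay. The expected step is a number 1.6 percentage points lower from compound 1 to compound 3 (within the scatter). Compound 3 is estimated at 52%, with an expected range of 36% to 68%.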

Compound 3, percent growth inhibition at one concentration: 38.6%
For compound 3 the middle estimate is 13.4 percentage points above the measured one, and the stated range covers the measured number.
By their numbers in this assay, from the lowest: compounds 3, 2 and 1 (each within the scatter of the next, the first and the last beyond it).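

In this assay, going by these compounds alone, tert-butyl in place of ethyl gives a number 15 percentage points lower from compound 1 to compound 3 (beyond the scatter), the first step beyond the scatter. This position therefore does not treat these two carbon-only groups alike, even though neither adds a ring, a charge or a hydrogen-bond donor or acceptor. Nothing available here accounts for the step.

Whether it goes with branching or with the carbon count stays open, as ethyl and tert-butyl are the only alkyl groups shown at this position. Isopropyl, a longer straight chain or an amine there would help separate these readings.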